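This account rests on a few compounds, and the source may have more. Where it says the series, first, only, none or still open, it means among the compounds named here.

Compound 1 `CC(=O)OC[C@H]1O[C@H](OC[C@H](Cn2cc(COc3ccc(-c4noc(NC5CCCCC5)n4)cc3)nn2)OC(C)=O)C=C[C@@H]1OC(C)=O`: 33.3 ug/mL
Compound 2 `CC(=O)OC[C@H]1O[C@H](OC[C@@H](Cn2cc(CN(c3nc(-c4ccc(Cl)cc4)no3)C3CCCCC3)nn2)OC(C)=O)C=C[C@@H]1OC(C)=O`: 35.5 ug/mL

Two compounds of this series have been examined in an ADME assay on RAW264.7 cells (Mus musculus) for cytotoxicity, read by MTT assay, with a stated time of 48 h; on this read-out lower numbers stand for higher toxicity in this test and higher numbers for lower toxicity in this test. In this assay compound 1 gives 33.3 ug/mL, and in this assay compound 2 gives 35.5 ug/mL. Compound 2 holds the higher of the two numbers, but its gap to compound 1 lies within the scatter of repeated measurements, so the two compounds cannot be told apart on these results.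

Compound 3 `CC(=O)OC[C@H]1O[C@H](OC[C@@H](Cn2cc(CN(c3nc(-c4cccc([N+](=O)[O-])c4)no3)C3CCCCC3)nn2)OC(C)=O)C=C[C@@H]1OC(C)=O` has not yet been measured. It departs from compound 2 in a single place: 3-nitrophenyl in place of 4-chlorophenyl on an aromatic carbon. Going by the values given here, no comparable exchange on any measured pair of this series is available, so there is no precedent in this assay for what such a change does. The expectation therefore rests on the closeness of compound 1 and compound 2, which suggests that this region of the molecule has so far tolerated variation without a shift beyond the scatter. Compound 3 is consequently expected to give 33 ug/mL in this assay, with a plausible range of 15 ug/mL to 70 ug/mL. The estimated step of a 1.1-fold lower number from compound 2 to compound 3 (0.03 log units; within the scatter) is thus expected to be none beyond the scatter, in either direction.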

Compound 3, half-maximal cytotoxic concentration: 100 ug/mL
Compound 3: middle estimate off by 3.0-fold (0.48 log units), on the low side; measured number outside the range, above it.
By their numbers in this assay, from the lowest: compounds 1 and 2 (each within the scatter of the next); then compound 3.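

In this assay, going by these compounds alone, the exchange of 4-chlorophenyl for 3-nitrophenyl on the aromatic carbon between two ring nitrogen atoms gives a 2.8-fold higher number from compound 2 to compound 3 (0.45 log units; beyond the scatter), which is the first single-place step available. It shows that the group at this position can move the number beyond the scatter, here in the direction of lower toxicity in this test, although the step is modest. The exchange alters both the substituent on the phenyl ring and where that substituent sits, and nothing available here explains the shift.

The compounds shown leave open whether the step belongs to the nitro group or to its place on the phenyl ring, a question on which 3-chlorophenyl and 4-nitrophenyl at the same carbon would bear. Also open, as far as these compounds go, is how an unsubstituted phenyl, or a phenyl carrying an amine or a carboxylic acid, would read in this assay, and whether the same exchange would act alike on the core of compound 1.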